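A few compounds are considered here, and "the series" means these few. Any claim that something is new, unique, unknown or untested is made for them only; others in the source may bear on it.

Compound 3, `O=C(NO)c1ccc(NCc2nc(-c3ccncc3)nn2-c2ccccc2)cc1`, sits at the bottom of the three measured numbers: in an assay on Sf9 cells for inhibition of protein deacetylase HDAC6 (Homo sapiens), read by fluorescence, with a stated time of 40 min, tested at 100 nM (on this read-out higher numbers stand for more inhibition at the one concentration tested (going by the name of the read-out) and lower numbers for less inhibition), compound 3 gives 30.8%. Compound 1, `O=C(NO)c1ccc(NCc2nc(-c3ccc(Br)cc3)nn2-c2ccccc2)cc1`, gives 54.7%, and compound 2, `O=C(NO)c1ccc(NCc2nc(-c3ccccn3)nn2-c2ccccc2)cc1`, gives 58.6%. The step of a number 23.9 percentage points lower from compound 1 to compound 3 (beyond the scatter) and the step of a number 27.8 percentage points lower from compound 2 to compound 3 (beyond the scatter) both run downhill and both lie beyond the scatter, while the step of a number 3.9 percentage points higher from compound 1 to compound 2 (within the scatter) stays within it.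

The unmeasured compound 4, `O=C(NO)c1ccc(NCc2nc(-c3ccc(C(F)(F)F)cc3)nn2-c2ccccc2)cc1`, differs from compound 3 in one place: 4-(trifluoromethyl)phenyl in place of pyridin-4-yl on an aromatic carbon. The step that bears most closely on this change is a number 23.9 percentage points lower from compound 1 to compound 3 (beyond the scatter), since compound 1 likewise carries a six-membered ring of carbon only with a group at the same position of that ring, and reversing that step would point upward. The step of a number 27.8 percentage points lower from compound 2 to compound 3 (beyond the scatter) points the same way, though compound 2 carries a ring with a hetero atom and so is a looser guide.

Compound 4 is therefore expected to recover roughly what compound 1 shows, so the step of a number 21.2 percentage points higher from compound 3 to compound 4 (beyond the scatter) is estimated to run upward beyond the scatter. The expected value for compound 4 is 52%, within a range from 35% to 70%.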

Compound 4, a percentage reported as inhibition, at one concentration (the size of the read-out at that concentration, not a potency): 41.6%
The estimate for compound 4 lay 10.4 percentage points above the measured number; the measured number falls inside the stated range.
By their numbers in this assay, from the lowest: compound 3; then compound 4; then compounds 1 and 2 (each within the scatter of the next).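

In this assay the change from pyridin-4-yl to 4-(trifluoromethyl)phenyl gives a number 10.8 percentage points higher from compound 3 to compound 4 (beyond the scatter) and so shows that a ring of carbon only can stand above pyridin-4-yl at this position, on the aromatic carbon between two ring nitrogen atoms, without matching the bromo compound. Trifluoromethyl in place of bromo gives a number 13.1 percentage points lower from compound 1 to compound 4 (beyond the scatter), which shows that with the ring of carbon only kept, the group it carries still moves the number by more than the scatter. Pyridin-2-yl in the same place is no lower, as a number 17 percentage points lower from compound 2 to compound 4 (beyond the scatter) shows, so the two rings with a hetero atom fall on opposite sides of compound 4 and no simple split between rings with and without nitrogen holds across these compounds.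

Nothing available explains why these groups rank as they do. Open too, going by these compounds, is where a plain phenyl, a pyridin-3-yl or a 4-aminophenyl group would fall at this position, and whether the order seen at this one concentration would persist for a 4-carboxyphenyl group or a longer chain.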